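The compounds below may be only part of what the source reports. "The series", "measured", "known", "first", "only" and "open" are said of these compounds alone.

Compound 1, `Cc1ccc(C(=O)/C=C/c2ccc3c(c2)B(O)OC3)cc1`, in an ADME assay on L929 cells (Mus musculus) for cytotoxicity, read by resazurin assay, with a stated time of 72 h (a higher number here means a weaker inhibitor, a lower number a stronger inhibitor), gives > 10 ug/mL, which is a limit of the assay and not a number.
Compound 2, `O=C(/C=C/c1ccc2c(c1)B(O)OC2)c1ccc(OCc2ccccc2)cc1`, in this assay gives > 10 ug/mL, again a limit rather than a number.

Compound 1 therefore stands only at a limit; how far beyond it the true number lies is not shown. Going by the values given here, the single measured step, a step that the two limits leave unreadable from compound 1 to compound 2, has no readable size because of the limit of > 10 ug/mL in this assay, at which 2 of the 2 values shown sit, so it gives no guide to how much this part of the structure can be changed before the read-out moves.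

Compound 3, `O=C(/C=C/c1ccc2c(c1)B(O)OC2)c1ccccc1F`, differs from compound 1 by 2-fluorophenyl in place of 4-methylphenyl on a carbonyl carbon. Among the compounds with values here, no measured step touches the group on the carbonyl carbon, so no step beyond the scatter is expected; the estimated step that the limit leaves unreadable from compound 1 to compound 3 is expected to be small. Compound 3 is estimated at 15 ug/mL, between 5 ug/mL and 50 ug/mL, and most likely the assay again reports only a limit.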

Compound 3, half-maximal inhibitory concentration: > 10 ug/mL
Compound 3 ended at the assay's limit; the forecaster's own chance of this, stated with the estimate: 75%; the middle value is on the limit's open side.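

The step from compound 1 to compound 3 cannot be read, because both compounds give a limit and not a number: the limit of > 10 ug/mL in this assay, at which 3 of the 3 values shown sit.
The compounds shown leave open how far past that limit each true value lies, and whether any change on the carbonyl carbon would give a measurable number.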